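Bromo for Chloro on Two Related Cores

This account rests on a few compounds, and the source may have more. Where it says the series, first, only, none or still open, it means among the compounds named here.

Measured in a functional assay on the whole organism for inhibition, with Rattus norvegicus as the target, read by paw edema, with a stated time of 2 h, at a dose of 50 mg/kg; a lower number here means less inhibition, a higher number more inhibition at the dose given (going by the name of the read-out):
compound 1, `CC(=O)c1c(NNc2ccc(Cl)cc2)cc(C)oc1=O`, gives 57.3%
compound 2, `CC(=O)c1c(NNc2ccc(Br)cc2)cc(C)oc1=O`, gives 47.2%
compound 3, `Cc1cc2nn(-c3ccc(Cl)cc3)c(C)c2c(=O)o1`, gives 59.6%

Compound 1 and compound 2 share one core; compound 3 is built on another, and the difference between the two cores is not broken down here. The change between the first two is bromo in place of chloro on an aromatic carbon. In this assay this gave a number 10.1 percentage points lower from compound 1 to compound 2 (beyond the scatter). Compound 3 and compound 1 lie within the scatter of each other, while compound 2 stands lower than compound 3 by more than the scatter.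

Compound 4, `Cc1cc2nn(-c3ccc(Br)cc3)c(C)c2c(=O)o1`, has not yet been measured in this assay. It differs from compound 3 by bromo in place of chloro on an aromatic carbon, the same change as between compound 1 and compound 2, at a place described in the same words. Going by the values given here, the only guide to its effect is the single step already seen; on the second core its size is unknown, and a move of a few points either way beyond that would not be surprising. Because the same change gave a number 10.1 percentage points lower from compound 1 to compound 2 (beyond the scatter), the expected step is a number 8.6 percentage points lower from compound 3 to compound 4 (within the scatter). Compound 4 is estimated at 51%, with a likely range from 38% to 62%.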

Compound 4, a percentage reported as inhibition, in the whole organism at one dose (the size of the read-out at that dose, not a potency): 50.6%
Compound 4: the middle estimate sits 0.4 percentage points above what was measured; low and high end bracket the measured number.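

In this assay, bromo in place of chloro on an aromatic carbon gave a number 9 percentage points lower from compound 3 to compound 4 (within the scatter) on the second core, and set beside the earlier step, the change carried from one core to the other with no difference that the numbers can separate: the same change on two cores in this assay, a number 10.1 percentage points lower (beyond the scatter) from compound 1 to compound 2 and a number 9 percentage points lower (within the scatter) from compound 3 to compound 4, 1.1 percentage points apart, within the scatter of two such steps. Taken alone, the new step lies within the scatter and does not separate compound 3 from compound 4, and the support for a shared effect comes from the agreement of the two steps rather than from either one. Going by these compounds alone, this agreement rests on only two cores and one exchange of groups at a single dose and time, and it does not show that the change would behave alike on any further core, nor does it explain why the two steps agree.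

The compounds shown carry only chloro or bromo at this place, which leaves open how fluoro, methoxy or a carboxylic acid there would read in this assay on either core. Also open, on these data alone, is whether the two steps would stay alike at other doses or at other times after dosing.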